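The source may report more compounds than this note shows. Statements on the series, on what has been measured and on what is new or still open speak of the compounds shown alone.

Compound 1 `Cc1ccc(-n2nncc2CN2C(=O)C3(C(C#N)=C(N)Oc4c3c3nc5ccccc5nc3c3ccccc43)c3ccccc32)cc1C` gives > 50000 nM in a functional assay on HCT-116 cells (Homo sapiens) for antiproliferative activity, read by MTT assay, with a stated time of 48 h (a lower number here means a stronger inhibitor, a higher number a weaker inhibitor), a limit of the assay rather than a number.
Compound 2 `Cc1ccc(-n2nncc2CN2C(=O)C3(C(C#N)=C(N)Oc4c3c3nc5ccccc5nc3c3ccccc43)c3ccccc32)c(C)c1` gives > 50000 nM in this assay, again a limit.
Compound 3 `COc1ccc(-n2nncc2CN2C(=O)C3(C(C#N)=C(N)Oc4c(N)cc5nc6ccccc6nc5c43)c3ccccc32)cc1` gives > 50000 nM in this assay, also a limit.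

Compound 3 thus stands at the edge of what this assay can read, and the limit of > 50000 nM in this assay, at which 3 of the 3 values shown sit, covers every value shown. Compound 4 `COc1cc(-n2nncc2CN2C(=O)C3(C(C#N)=C(N)Oc4c(N)cc5nc6ccccc6nc5c43)c3ccccc32)c(OC)cc1Cl` differs from compound 3 only at one place: 4-chloro-2,5-dimethoxyphenyl in place of 4-methoxyphenyl on an aromatic nitrogen. Among the compounds with values here, the single measured step that swaps the group on that same aromatic nitrogen, a step that the two limits leave unreadable from compound 1 to compound 2, is unreadable. Nothing measured here shows that changing this group moves potency off the limit, so compound 4 is expected to remain there, the step of a number no higher from compound 3 to compound 4 (the limit leaves the size open) being an estimate of no readable change. Compound 4 is therefore estimated at 50000 nM, within the range 20000 nM to 150000 nM.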

Compound 4, half-maximal inhibitory concentration: > 50000 nM
Compound 4: no number, only a limit (the forecaster's own chance of this, stated with the estimate: 85%); the middle value lies on the limit itself.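

In this assay compound 3 and compound 4 both give only a limit, and the step between them cannot be read. The compounds shown leave open whether any group on that aromatic nitrogen gives a readable potency.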